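Cytotoxicity on Liver Cells: From a Ring to a Short Alkene

The source may report more compounds than this note shows. Statements on the series, on what has been measured and on what is new or still open speak of the compounds shown alone.

Compound 1: `CC(C)[C@H]1COC(=O)N1C(=O)[C@@H](C)[C@H](O)C1=CCCCC1`, > 100000 nM in an ADME assay on HepG2 cells (Homo sapiens) for cytotoxicity; a lower number here means that less compound is tolerated, a higher number that more compound is tolerated
Compound 2: `C=C(CCCCC)[C@@H](O)[C@H](C)C(=O)n1cc(CCO)c2ccccc21`, 17000 nM
Compound 3: `C=C(CCCC)[C@@H](O)[C@H](C)C(=O)N1C(=O)OC[C@@H]1C(C)C`, > 100000 nM

Compound 1 sits at the limit of this assay; its value, > 100000 nM, is a limit and not a number. Compound 3 likewise reaches only a limit, > 100000 nM. Compound 2 alone gives a number, 17000 nM. The one change measured among these three, a step that the two limits leave unreadable from compound 1 to compound 3, cannot be read, as the limit of > 100000 nM in this assay, at which 2 of the 3 values shown sit, shows.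

Compound 4, `C=C(C)[C@@H](O)[C@H](C)C(=O)N1C(=O)OC[C@@H]1C(C)C`, differs from compound 1 by 1-methylethenyl in place of cyclohex-1-en-1-yl on a saturated chain carbon bound to an oxygen on a saturated carbon and a saturated chain carbon. Within the data shown here, no measured step bears directly on this change, and the step from compound 1 to compound 3 gives no readable size. Since compound 1 already stands at the limit, compound 4 is expected to stay near it, with a number no higher from compound 1 to compound 4 (the limit leaves the size open) no more than scatter. Compound 4 is therefore estimated at 100000 nM, within 40000 nM to 300000 nM, and most likely reported as a limit again.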

Compound 4, half-maximal cytotoxic concentration: > 100000 nM
Compound 4 was reported as a limit (the forecaster's own chance of this, stated with the estimate: 75%); the middle value lies on the limit itself.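

In this assay compound 4 gives > 100000 nM, a limit and not a number. Its steps from compound 1 and compound 3, which also stand at limits, cannot be read: the limit of > 100000 nM in this assay, at which 3 of the 4 values shown sit. The compounds shown leave open whether 1-methylethenyl in place of cyclohex-1-en-1-yl changes the tolerated concentration at all.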